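Fluorophenyl Urea Series: Fluorine Position With a Ring Carboxamide

The compounds below may be only part of what the source reports. "The series", "measured", "known", "first", "only" and "open" are said of these compounds alone.

Measured so far:
Compound 1 `O=C(Nc1cccc(F)c1)N1c2ccnn2CC1c1ccccc1` — 12.1 nM
Compound 2 `CCOC(=O)c1cnn2c1N(C(=O)Nc1cccc(F)c1)C(c1ccccc1)C2` — 9.2 nM
Compound 3 `NC(=O)c1cnn2c1N(C(=O)Nc1ccccc1F)C(c1ccccc1)C2` — > 1000 nM

In a functional assay on cells (Neutrophil, Homo sapiens) for inhibition, with a stated time of 10 min (on this read-out higher numbers stand for weaker inhibition and lower numbers for stronger inhibition), compound 1 gives 12.1 nM and compound 2 gives 9.2 nM; the step of a 1.3-fold lower number from compound 1 to compound 2 (0.12 log units; within the scatter) shows that ethoxycarbonyl on the aromatic carbon is tolerated. Compound 3 returns only a limit in this assay, > 1000 nM, and so carries no number. Compound 3 stands at the limit of > 1000 nM in this assay, at which 1 of the 3 values shown sits. Compound 3 differs from the other two in two places at once, a primary carboxamide on the aromatic carbon and a 2-fluorophenyl on the urea nitrogen, so the values shown cannot tell which of the two carries the loss.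

Compound 4 `NC(=O)c1cnn2c1N(C(=O)Nc1cccc(F)c1)C(c1ccccc1)C2` is still to be measured. It differs from compound 3 by 3-fluorophenyl in place of 2-fluorophenyl on an amide-type nitrogen. Going by the values given here, no measured step covers this change; the only measured step, a 1.3-fold lower number from compound 1 to compound 2 (0.12 log units; within the scatter), concerns a different part of the molecule and lies within the scatter. Compound 4 carries the 3-fluorophenyl of compounds 1 and 2 together with the carboxamide of compound 3, so its value is expected to land between those two groups. Compound 4 is estimated at 150 nM, within 20 nM to 1500 nM. Set against the limit of compound 3, this is the expected step of an at least 6.6-fold lower number from compound 3 to compound 4 (0.82 log units; beyond the scatter), with wide uncertainty since compound 3 supplies a limit rather than a number.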

Compound 4, half-maximal inhibitory concentration: 3.9 nM
Compound 4: the middle estimate sits 38-fold (1.59 log units) above what was measured, outside the stated range (below it).
By their numbers in this assay, from the lowest: compound 4; then compounds 2 and 1 (each within the scatter of the next). At a limit, above all of these: compound 3.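

In this assay, with the carboxamide held fixed, 3-fluorophenyl in place of 2-fluorophenyl on the amide-type nitrogen gives an at least 250-fold lower number from compound 3 to compound 4 (2.40 log units; beyond the scatter), so the loss at compound 3 goes with the 2-fluorophenyl and not with the carboxamide. The carboxamide is more than tolerated alongside the 3-fluorophenyl: carbamoyl in place of hydrogen on the aromatic carbon gives a 3.1-fold lower number from compound 1 to compound 4 (0.49 log units; beyond the scatter), and amino in place of ethoxy on the carbonyl carbon gives a 2.4-fold lower number from compound 2 to compound 4 (0.37 log units; beyond the scatter). Compound 3 stands at a limit and not at a number, so the true size of the fluorine step remains unknown and only its lower bound is read: the limit of > 1000 nM in this assay, at which 1 of the 4 values shown sits.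

As far as these compounds go, the 2-fluorophenyl appears here only with the carboxamide, so it remains open whether it costs as much on the core of compound 1 or with the ethoxycarbonyl of compound 2. Also open, from the compounds shown here alone, is how a 4-fluorophenyl or an unsubstituted phenyl on the amide-type nitrogen, or a carboxylic acid on the aromatic carbon, would stand in this assay.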